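Predicting a Methyl Step for Compound 4

The compounds below may be only part of what the source reports. "The series", "measured", "known", "first", "only" and "open" are said of these compounds alone.

Compound 1 `CCC[C@]1(c2ccccc2)OC[C@H]([C@@H]2CCCCN2)O1` gives 69 nM in a functional assay (brain) for displacement of a labelled ligand, with Rattus norvegicus as the target; a higher number here means a weaker inhibitor, a lower number a stronger inhibitor. Compound 2 `CCCC[C@]1(c2ccccc2)OC[C@H]([C@@H]2CCCCN2)O1` carries methyl in place of hydrogen on a saturated chain carbon, three bonds along the chain from a saturated ring carbon, and in this assay compound 2 gives 200 nM, the step being a 2.9-fold higher number from compound 1 to compound 2 (0.46 log units; beyond the scatter). Compound 3 `CCNC[C@H]1COC(c2ccccc2)(c2ccccc2)O1` rests on a different core; the difference between the two cores is not broken down here. In this assay compound 3 gives 8400 nM, the highest of the three numbers. Compound 4 `CCN[C@@H](C)[C@H]1COC(c2ccccc2)(c2ccccc2)O1` has not been measured and carries methyl in place of hydrogen on a saturated chain carbon bound to an amine nitrogen and a saturated ring carbon. This is the same kind of change as in the measured pair, yet the place differs: there the methyl enters on a saturated chain carbon three bonds along the chain from a saturated ring carbon, here on a saturated chain carbon bound to an amine nitrogen and a saturated ring carbon. Because compound 1 and compound 2 show a 2.9-fold higher number from compound 1 to compound 2 (0.46 log units; beyond the scatter), the expected step is a 1.9-fold higher number from compound 3 to compound 4 (0.28 log units; within the scatter). Compound 4 is therefore estimated at 16000 nM, with a likely range from 4000 nM to 60000 nM.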

Compound 4, inhibition constant: 9000 nM
For compound 4 the middle estimate is 1.8-fold (0.25 log units) above the measured one, within the range that was stated.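

In this assay, with methyl in place of hydrogen on a saturated chain carbon bound to an amine nitrogen and a saturated ring carbon, the step is a 1.1-fold higher number from compound 3 to compound 4 (0.03 log units; within the scatter). Set beside the earlier step, the change did not carry over in size from one core to the other: the same change on two cores in this assay, a 2.9-fold higher number (0.46 log units; beyond the scatter) from compound 1 to compound 2 and a 1.1-fold higher number (0.03 log units; within the scatter) from compound 3 to compound 4, 2.7-fold (0.43 log units) apart, beyond the scatter of two such steps. The two steps differ in both the core and the place of the methyl, and the data do not separate these two, while a single pair on each core gives no rule for the series.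

The compounds shown leave open how a hydroxyl group or a fluorine in place of that methyl would read at the same carbon. They also leave open whether the methyl would give a similar step at this place on the core of compound 1.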